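Aminophenyl regiochemistry in a thiazolidinedione-type series

The source may hold more compounds than are shown below. What is called first, only, known or untested is meant among the compounds shown, and "the series" means these compounds.

Of the compounds shown here, three have been measured in a functional assay on HeLa cells (Homo sapiens) for cytotoxicity, read by cell counting, with a stated time of 4 days; on this read-out higher numbers stand for weaker inhibition and lower numbers for stronger inhibition. Compound 1 `CC(C)(C)c1ccc(CN2C(=O)S/C(=C\c3cccc(N)c3)C2=O)cc1` gives 145000 nM. Compound 2 `C=C(Br)C(=O)Nc1cccc(/C=C2\SC(=O)N(Cc3ccc(F)cc3)C2=O)c1` gives 800 nM. Compound 3 `Nc1ccc(/C=C2\SC(=O)N(Cc3ccc(F)cc3)C2=O)cc1` gives 186000 nM, the highest of the three numbers; against compound 1 the gap is within the scatter, while against compound 2 it lies well beyond it. Among the measured compounds shown here, no pair of measured compounds differs in a single place, so no step can be read off directly.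

Compound 4 `Nc1cccc(/C=C2\SC(=O)N(Cc3ccc(F)cc3)C2=O)c1` is not yet measured. It differs from compound 3 in one place: 3-aminophenyl in place of 4-aminophenyl on a double-bonded chain carbon bound to a double-bonded ring carbon. Compound 4 thus carries the 3-aminophenyl also present in compound 1, whose value of 145000 nM sits close to compound 3. On that basis no step beyond the scatter is expected, and the estimated step of a 1.2-fold lower number from compound 3 to compound 4 (0.09 log units; within the scatter) is essentially flat. Compound 4 is expected to give about 150000 nM in this assay, with a range from 60000 nM to 350000 nM.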

Compound 4, half-maximal inhibitory concentration: 86000 nM
For compound 4 the middle estimate is 1.7-fold (0.24 log units) above the measured one, and the stated range covers the measured number.
By their numbers in this assay, from the lowest: compound 2; then compounds 4, 1 and 3 (each within the scatter of the next, the first and the last beyond it).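

In this assay the place on a double-bonded chain carbon bound to a double-bonded ring carbon proves sensitive to the amino position, though only slightly: 3-aminophenyl in place of 4-aminophenyl gives a 2.2-fold lower number from compound 3 to compound 4 (0.34 log units; beyond the scatter), a modest step. The (1-bromoethenyl)carbonyl on the nitrogen carries far more weight, since its replacement by hydrogen gives a 110-fold higher number from compound 2 to compound 4 (2.03 log units; beyond the scatter), a large step. With 3-aminophenyl held fixed, fluoro in place of tert-butyl gives a 1.7-fold lower number from compound 1 to compound 4 (0.23 log units; within the scatter), so these two groups on the aromatic carbon cannot be told apart in this series.

Nothing on hand bears on the reason for any of these steps. Still open, as far as these compounds go, is whether the large step needs the bromine or the double bond, which an acetyl or a propanoyl on the same nitrogen would test.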